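This account rests on a few compounds, and the source may have more. Where it says the series, first, only, none or still open, it means among the compounds named here.

For the measured compounds named here, in a functional assay on cells (Panel melanoma (Carcinoma cell lines), Homo sapiens) for inhibition, read by sulforhodamine B assay, with a stated time of 48 h (on this read-out higher numbers stand for weaker inhibition of growth and lower numbers for stronger inhibition of growth), the three compounds measured so far sit close together. Compound 1 `CN1CCN(CCCOc2cccc3nc(Nc4ccc(Cl)c(F)c4)ccc23)CC1` gives 3500 nM. Compound 2 `CN1CCN(CCCOc2cccc3nc(Nc4ccc(F)c(F)c4)ccc23)CC1` gives 4400 nM. Compound 3 `CN1CCN(CCCOc2cccc3nc(Nc4cc(Cl)cc(Cl)c4)ccc23)CC1` gives 3430 nM, the lowest of the three numbers, though its steps to both others are within the scatter: a 1.0-fold lower number from compound 1 to compound 3 (0.01 log units; within the scatter) and a 1.3-fold lower number from compound 2 to compound 3 (0.11 log units; within the scatter). Likewise a 1.3-fold higher number from compound 1 to compound 2 (0.10 log units; within the scatter). Across these three, exchanging or rearranging the halogens on the phenyl group on the nitrogen has moved nothing beyond the scatter.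

Compound 4 `CN1CCN(CCCOc2cccc3nc(Nc4cccc(Cl)c4)ccc23)CC1` differs from compound 3 in that (hydrogen in place of chloro on an aromatic carbon). Going by the values given here, no measured step removes a halogen outright; the three steps recorded only swap one halogen for another or shift their pattern on that phenyl group, and each was within the scatter. The data give no indication that a single halogen on this group carries a measurable share of the growth inhibition. On that basis the step in this assay from compound 3 to compound 4 is expected to be small, with no direction beyond the scatter. For compound 4 the expected step is a 1.1-fold higher number from compound 3 to compound 4 (0.04 log units; within the scatter). Compound 4 is therefore estimated at 3800 nM, with a range from 1800 nM to 8000 nM.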

Compound 4, concentration for total growth inhibition: 3370 nM
Beside the measured number, compound 4's estimate is 1.1-fold (0.05 log units) above it, and the stated range covers the measured number.
By their numbers in this assay, from the lowest: compounds 4, 3, 1 and 2 (each within the scatter of the next).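

Removing a halogen outright, rather than swapping or shifting one, leaves the read-out in this assay unmoved: going from 3,5-dichlorophenyl to 3-chlorophenyl gives a 1.0-fold lower number from compound 3 to compound 4 (0.01 log units; within the scatter). With only one halogen on this group, the number also stays within the scatter of both remaining analogues, with a 1.0-fold lower number from compound 1 to compound 4 (0.02 log units; within the scatter) and a 1.3-fold lower number from compound 2 to compound 4 (0.12 log units; within the scatter), so among these four compounds neither the second halogen nor the pattern of halogens carries a measurable share of the growth inhibition. No available measurement accounts for this flat response to the loss of chloro at this position.

Still open is whether the flat response holds once the remaining chloro is also replaced by hydrogen, since every compound shown keeps at least one halogen on this phenyl group. Equally open, from the compounds shown here alone, is whether a group of another kind on that ring, such as a methoxy group, an amine or a carboxylic acid, or a longer chain to the methylpiperazine, would move the number beyond the scatter.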